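The source may report more compounds than this note shows. Statements on the series, on what has been measured and on what is new or still open speak of the compounds shown alone.

Measured so far:
compound 1 `Cc1ccc(S(=O)(=O)NCc2ccc(CNC(=O)c3ccc([N+](=O)[O-])cc3)cc2)cc1` gives 10 nM
compound 2 `COc1ccccc1C(=O)NCc1ccc(CNS(=O)(=O)c2ccccc2)cc1` gives 1 nM

Both numbers come from an assay on MDA-MB-231 cells for binding affinity to C-X-C chemokine receptor type 4 (Homo sapiens), read by immunofluorescence and microscopy, with stated times of 10 min and 30 min; a higher number here means that more compound is needed for the effect, a lower number that less compound is needed. Among these two, compound 1 stands with the higher number, and compound 2 shows a lower number than compound 1, a gap that lies beyond the usual scatter. The two structures differ in more than one place, so what the two values show cannot be tied to any single change. Compound 3 `Cc1ccc(S(=O)(=O)NCc2ccc(CNC(=O)c3ccccc3Cl)cc2)cc1` has not been measured yet. It differs from compound 1 in one place: 2-chlorophenyl in place of 4-nitrophenyl on a carbonyl carbon. Within the data shown here, no measured pair shows a step of this kind, so its size is uncertain; a modest move to a lower number is expected, with a move in the other direction not ruled out. The step from compound 1 to compound 3 is expected to be a 2.0-fold lower number from compound 1 to compound 3 (0.30 log units; within the scatter). For compound 3 the estimated value is 5 nM, with an expected range from 1.5 nM to 20 nM.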

Compound 3, effective concentration (reported as EC, without a stated level of effect): 10 nM
Compound 3: the middle estimate sits 2.0-fold (0.30 log units) below what was measured; the range from low to high includes it.
By their numbers in this assay, from the lowest: compound 2; then compounds 1 and 3 (each within the scatter of the next).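

Putting 2-chlorophenyl in place of 4-nitrophenyl on a carbonyl carbon gives no change at the digits printed from compound 1 to compound 3 (within the scatter) in this assay. Among these compounds, this is the first change in a single place that can be read, and the number holds even though the 2 hydrogen-bond acceptors of 4-nitrophenyl are gone and the entering group has fewer heavy atoms. No measurement available here bears on why these two groups give matching numbers.

On these data alone, whether a different kind of group on this carbonyl carbon, such as a carboxylic acid or an amine, would shift the number remains open. Also open is what lies behind the value of compound 2, 1 nM, which differs in more than one place from both other compounds and so cannot be tied to a single change.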